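Three quinazoline-type compounds at the tolerance limit, one more

A few compounds are considered here, and "the series" means these few. Any claim that something is new, unique, unknown or untested is made for them only; others in the source may bear on it.

Compound 1, `CCCCC[Se]c1nc(NCc2ccc(SC)cc2)c2ccccc2n1`: in a functional assay on HT-29 cells (Homo sapiens) for cytotoxicity, read by MTT assay, with a stated time of 72 h (a lower number here means that less compound is tolerated, a higher number that more compound is tolerated), compound 1 gives > 100000 nM, which is a limit of the assay.
Compound 2, `CSc1nc(NCc2ccc([Se]C)cc2)c2ccccc2n1`: in this assay compound 2 gives > 100000 nM, also a limit.
Compound 3, `CSc1nc(NCc2ccccc2)c2ccccc2n1`: in this assay compound 3 gives > 100000 nM, again a limit.

Among the measured compounds shown here, compound 3 therefore stands where every value so far stands, at the limit of > 100000 nM in this assay, at which 3 of the 3 values shown sit. Compound 4, `CSc1ccc(CNc2nc(SC)nc3ccccc23)cc1`, differs from compound 3 by methylsulfanyl in place of hydrogen on an aromatic carbon. For the measured compounds named here, the only step that bears on this change is a step that the two limits leave unreadable from compound 2 to compound 3. Both of its ends are limits, and it yields no readable size. The change to compound 4 is expected to leave it at the same limit, so the step from compound 3 to compound 4 is estimated as a step that the limit leaves unreadable from compound 3 to compound 4. For compound 4 in this assay the estimate is 150000 nM, spanning 50000 nM to 500000 nM.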

Compound 4, concentration lethal to 50% of the cells: > 100000 nM
Compound 4: a limit, no number; the forecaster's own chance of this, stated with the estimate: 85%; the middle value is on the limit's open side.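

The result for compound 4 is a limit, so its steps from compound 1, compound 2 and compound 3 cannot be read. The compounds shown leave open whether any of these changes alters what is tolerated in this assay.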